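The source may report more compounds than this note shows. Statements on the series, on what has been measured and on what is new or still open speak of the compounds shown alone.

Working notes on the series. Compound 3 `COc1cccc(-c2cc(-c3cc(C(C)C)c(O)cc3C)[nH]c(=O)c2C#N)c1` stands second highest of the three numbers in a functional assay for inhibition, tested at 100 ug/mL (a higher number here means a stronger effect of the compound at the concentration tested, a lower number a weaker effect), with 49%; its nearest neighbour is compound 2 `COc1cc(-c2cc(-c3cc(C(C)C)c(O)cc3C)[nH]c(=O)c2C#N)ccc1O` with 44%, and the step of a number 5 percentage points higher from compound 2 to compound 3 (within the scatter) lies within the scatter. Compound 1 `Cc1cc(O)c(C(C)C)cc1-c1cc(-c2ccco2)c(C#N)c(=O)[nH]1` sits furthest from it with 70%; the two aryl-for-furanyl steps, a number 26 percentage points lower from compound 1 to compound 2 (beyond the scatter) and a number 21 percentage points lower from compound 1 to compound 3 (beyond the scatter), are both modest losses beyond the scatter.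

The unmeasured compound 4 `Cc1cc(O)c(C(C)C)cc1-c1cc(-c2ccccc2)c(C#N)c(=O)[nH]1` differs from compound 3 by hydrogen in place of methoxy on an aromatic carbon. Among the measured compounds shown here, no measured step removes a methoxy, so the only direct guide is the hydroxy removal in a number 5 percentage points higher from compound 2 to compound 3 (within the scatter), which stayed within the scatter; the furan-to-aryl steps concern a different part of the molecule and do not bear on this change. A change of similar small size, in no clear direction, is therefore expected for a number 1 percentage points higher from compound 3 to compound 4 (within the scatter). Compound 4 is estimated at 50%, with a range from 35% to 65%.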

Compound 4, a percentage reported as inhibition, at one concentration (the size of the read-out at that concentration, not a potency): 41%
Compound 4: middle estimate off by 9 percentage points, on the high side, and the stated range covers the measured number.
By their numbers in this assay, from the lowest: compounds 4, 2 and 3 (each within the scatter of the next); then compound 1.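

In this assay the change from 3-methoxyphenyl to phenyl gives a number 8 percentage points lower from compound 3 to compound 4 (within the scatter), and the removal of both the hydroxy and the methoxy gives a number 3 percentage points lower from compound 2 to compound 4 (within the scatter); neither substituent on this six-membered aromatic ring therefore has an effect that can be told from the scatter. The step of a number 29 percentage points lower from compound 1 to compound 4 (beyond the scatter) shows that the loss against furan-2-yl also holds for the bare phenyl, so among these compounds it does not depend on either substituent. Nothing shown gives a reason for these steps.

Open, from the compounds shown here alone, is whether an amine, a carboxylic acid or a longer chain such as butoxy on the phenyl would move the number beyond the scatter. Also open, going by these compounds, is whether any aryl group at this place can match furan-2-yl, which in compound 1 gives 70%; all three aryl groups tested here stay beyond the scatter from that number.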